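Stripping the amine down to a bare nitrogen on a six-carbon chain

The compounds below may be only part of what the source reports. "The series", "measured", "known", "first", "only" and "open" are said of these compounds alone.

Of the compounds shown here, three sharing one core have been tested in an assay on isolated protein (Cavia porcellus) with Sigma non-opioid intracellular receptor 1 (Homo sapiens) as the target, read by radioligand binding; a lower number here means a stronger inhibitor, a higher number a weaker inhibitor. Compound 1 `O=c1cc(-c2ccccc2)oc2ccc(OCCCN3CCC(O)CC3)cc12` gives 130 nM, compound 2 `CN(CCCCCCOc1ccc2oc(-c3ccccc3)cc(=O)c2c1)Cc1ccccc1` gives 52 nM, and compound 3 `CCOC(=O)C1CCN(CCCCCCOc2ccc3oc(-c4ccccc4)cc(=O)c3c2)CC1` gives 164 nM, the highest of the three numbers, though its gap to compound 1 lies within the usual scatter. Compound 4 `NCCCCCCOc1ccc2oc(-c3ccccc3)cc(=O)c2c1` differs from compound 3 only by amino in place of 4-(ethoxycarbonyl)piperidin-1-yl on a saturated chain carbon, six bonds along the chain from an oxygen on an aromatic ring. Among the measured compounds shown here, the one measured step at this same place, a 3.2-fold higher number from compound 2 to compound 3 (0.50 log units; beyond the scatter), shows that swapping the group on the chain nitrogen can shift this assay modestly. Compound 4 keeps even less on that nitrogen than either, so a further rise in the number is expected, a 2.4-fold higher number from compound 3 to compound 4 (0.39 log units; beyond the scatter). The estimate for compound 4 in this assay is 400 nM, within 120 nM to 1500 nM.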

Compound 4, half-maximal inhibitory concentration: 2100 nM
Beside the measured number, compound 4's estimate is 5.3-fold (0.72 log units) below it; the measured number lies above the stated range.
By their numbers in this assay, from the lowest: compound 2; then compounds 1 and 3 (each within the scatter of the next); then compound 4.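

In this assay, a bare amino group at this place on the chain costs far more (a 13-fold higher number from compound 3 to compound 4 (1.11 log units; beyond the scatter); a 40-fold higher number from compound 2 to compound 4 (1.61 log units; beyond the scatter)) than exchanging one substituted nitrogen for another did (a 3.2-fold higher number from compound 2 to compound 3 (0.50 log units; beyond the scatter)). The gap to compound 1 is also large (a 16-fold higher number from compound 1 to compound 4 (1.21 log units; beyond the scatter)), though that step swaps 4-hydroxypiperidin-1-yl for 3-aminopropyl and so changes the chain as well. Among these compounds, each nitrogen carrying carbon groups gives a lower number than the bare amino group.

From the compounds shown here alone, whether a small methylamino or dimethylamino group would recover most of the loss remains open. Nothing shown here explains the size of this rise.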